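Swapping One Para Group for Another on the Ketone Ring

A few compounds are considered here, and "the series" means these few. Any claim that something is new, unique, unknown or untested is made for them only; others in the source may bear on it.

Compound 3 `COc1cc(-c2nnc(SCC(=O)c3ccc(F)cc3)n2N)cc(OC)c1OC` stands highest of the two plain numbers measured in a functional assay on HeLa cells (Homo sapiens) for antiproliferative activity, read by MTT assay, with a stated time of 48 h; on this read-out lower numbers stand for stronger inhibition and higher numbers for weaker inhibition: compound 3 gives 20900 nM. Its nearest neighbour is compound 2 `COc1cc(-c2nnc(SCC(=O)c3ccc(Br)cc3)n2N)cc(OC)c1OC`, which in this assay gives 10400 nM, and the gap a 2.0-fold higher number from compound 2 to compound 3 (0.30 log units; within the scatter) lies within the usual scatter, so no order between them can be claimed. Compound 1 `COc1cc(-c2nnc(SCC(=O)c3ccccc3)n2N)cc(OC)c1OC`, with hydrogen where the others carry a halogen, gives in this assay only a limit, > 100000 nM, which is the limit of > 100000 nM in this assay, at which 1 of the 3 values shown sits. The steps of an at least 9.6-fold lower number from compound 1 to compound 2 (0.98 log units; beyond the scatter) and an at least 4.7-fold lower number from compound 1 to compound 3 (0.67 log units; beyond the scatter) both show that placing a group on that aromatic carbon lowers the number by at least a modest amount.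

Compound 4 `COc1ccc(C(=O)CSc2nnc(-c3cc(OC)c(OC)c(OC)c3)n2N)cc1` differs from compound 3 by methoxy in place of fluoro on an aromatic carbon of a six-membered aromatic ring of carbon only, para to a large group, so that the (4-fluorophenyl)carbonyl becomes a (4-methoxyphenyl)carbonyl. Going by the values given here, the step that bears most directly on this change is a 2.0-fold higher number from compound 2 to compound 3 (0.30 log units; within the scatter), the only measured exchange of one such group for another, and it stayed within the scatter. A similar outcome is expected here, with the step of a 1.4-fold lower number from compound 3 to compound 4 (0.14 log units; within the scatter) estimated as none beyond the scatter. Compound 4 is therefore expected to give about 15000 nM, within a range from 4000 nM to 60000 nM.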

Compound 4, half-maximal inhibitory concentration: 17400 nM
For compound 4 the middle estimate is 1.2-fold (0.06 log units) below the measured one, and the stated range covers the measured number.
By their numbers in this assay, from the lowest: compounds 2, 4 and 3 (each within the scatter of the next). At a limit, above all of these: compound 1.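

Methoxy brings a carbon and an oxygen where fluoro has a single fluorine, and it adds a hydrogen-bond acceptor, yet in this assay there is a 1.2-fold lower number from compound 3 to compound 4 (0.08 log units; within the scatter), and against the bromo group there is a 1.7-fold higher number from compound 2 to compound 4 (0.22 log units; within the scatter). The two halogens and methoxy therefore cannot be put in any order here, and the earlier gain over hydrogen is no longer tied to a halogen, since there is also an at least 5.7-fold lower number from compound 1 to compound 4 (0.75 log units; beyond the scatter). That last step is open-ended, as compound 1 has no plain number, only a limit of the assay: the limit of > 100000 nM in this assay, at which 1 of the 4 values shown sits.

Still open, on these data alone, is whether an amine, a carboxylic acid or a longer chain such as butoxy on this aromatic carbon would stay level with compound 2, compound 3 and compound 4, or would move the number clearly away from them. The compounds shown also cannot tell which feature these three groups share that separates them from hydrogen, or whether any group here could bring the number clearly lower.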